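This account rests on a few compounds, and the source may have more. Where it says the series, first, only, none or still open, it means among the compounds named here.

Compound 1 `O=C1Nc2ccc(Br)cc2/C1=N/NC(=S)Nc1ccc(Cl)cc1` gives 61000 nM in a functional assay on CCRF-CEM cells (Homo sapiens), with a stated time of 72 h; a lower number here means a stronger inhibitor, a higher number a weaker inhibitor. Compound 2 `Cc1ccc(NC(=S)N/N=C2\C(=O)Nc3ccc(Br)cc32)cc1` gives 6800 nM in this assay, a step of a 9.0-fold lower number from compound 1 to compound 2 (0.95 log units; beyond the scatter) for the change (methyl in place of chloro on an aromatic carbon). For compound 3 `Cc1ccc(NC(=S)N/N=C2\C(=O)N(Cc3ccc(Cl)cc3)c3ccc(Br)cc32)cc1` this assay reports only a limit, >= 500000 nM. The step from compound 2 is an at least 73-fold higher number from compound 2 to compound 3 (1.86 log units; beyond the scatter), and this value rests on (the limit of >= 500000 nM in this assay, at which 1 of the 3 values shown sits). How the core of compound 3 differs from that of compound 1 is not broken down here. Compound 4 `Cc1ccc(CN2C(=O)/C(=N\NC(=S)Nc3ccc(C)cc3)c3cc(Br)ccc32)cc1` repeats the same change on the core of compound 3, (methyl in place of chloro on an aromatic carbon), at a place described in the same words as before. Since compound 3 sits at a limit, the step from compound 3 to compound 4 in this assay is expected to be only an at least 1.6-fold lower number from compound 3 to compound 4 (0.22 log units; that floor lies within the scatter), with a good chance of another limit. Compound 4 is therefore estimated at 300000 nM, between 60000 nM and 1000000 nM.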

Compound 4, half-maximal inhibitory concentration: >= 500000 nM
Compound 4: no number, only a limit (the forecaster's own chance of this, stated with the estimate: 60%); middle value at least 1.6-fold (0.22 log units) away from the limit.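

In this assay compound 4 gives >= 500000 nM, a limit of the assay and not a number, and compound 3 also stands at a limit, so the step between them cannot be read: the limit of >= 500000 nM in this assay, at which 2 of the 4 values shown sit. The same change gave a 9.0-fold lower number from compound 1 to compound 2 (0.95 log units; beyond the scatter), but the data neither confirm nor refute that it carries over to the core of compound 3. What can be read is an at least 73-fold higher number from compound 2 to compound 4 (1.86 log units; beyond the scatter), for 4-methylbenzyl in place of hydrogen on the amide-type nitrogen, in the same direction as an at least 73-fold higher number from compound 2 to compound 3 (1.86 log units; beyond the scatter).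

The compounds shown leave open what an ethyl chain on that nitrogen, or a benzyl group bearing an amine or a carboxylic acid, would give. They also leave open whether methyl in place of chloro has any readable effect once that nitrogen carries a group.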